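The source may report more compounds than this note shows. Statements on the series, on what has been measured and on what is new or still open speak of the compounds shown alone.

Compound 1 `CCCC(c1ccccc1)n1ccc2cc(/C(C)=C/C(=O)Nc3ccccc3OCCCC(=O)O)ccc21`: in an assay on Prostate gland for inhibition of steroid 5-alpha-reductase (Rattus norvegicus) (a lower number here means a stronger inhibitor, a higher number a weaker inhibitor), compound 1 gives 9.1 nM.
Compound 2 `COc1ccc(C(c2ccccc2)n2ccc3cc(/C(C)=C/C(=O)Nc4ccccc4OCCCC(=O)O)ccc32)cc1`: in this assay compound 2 gives 8.8 nM.

Compound 2 thus stands side by side with compound 1, the two numbers lying within the usual scatter of each other. Among the measured compounds shown here, the one measured step, a 1.0-fold lower number from compound 1 to compound 2 (0.01 log units; within the scatter), exchanges the group on the saturated chain carbon bound to an aromatic carbon and an aromatic nitrogen and leaves the number essentially where it was.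

Compound 3 `C/C(=C\C(=O)Nc1ccccc1OCCCC(=O)O)c1ccc2c(ccn2C(c2ccccc2)c2ccncc2)c1` changes that same position once more: pyridin-4-yl in place of 4-methoxyphenyl on a saturated chain carbon bound to an aromatic carbon and an aromatic nitrogen. For the measured compounds named here, the only step that bears on it is the one from compound 1 to compound 2, which was within the scatter; on that basis a further exchange of the aryl group at this position is expected to move this assay little, if at all, in either direction. Compound 3 is therefore estimated at 10 nM, with a range from 4 nM to 25 nM, which means an expected step of a 1.1-fold higher number from compound 2 to compound 3 (0.06 log units; within the scatter).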

Compound 3, half-maximal inhibitory concentration: 26 nM
For compound 3 the middle estimate is 2.6-fold (0.41 log units) below the measured one, outside the stated range (above it).
By their numbers in this assay, from the lowest: compounds 2 and 1 (each within the scatter of the next); then compound 3.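

In this assay this position proves not to be indifferent to what it carries: pyridin-4-yl in place of 4-methoxyphenyl gives a 3.0-fold higher number from compound 2 to compound 3 (0.47 log units; beyond the scatter) and so a modest loss that the earlier exchange gave no sign of. Pyridin-4-yl in place of propyl likewise gives a 2.9-fold higher number from compound 1 to compound 3 (0.46 log units; beyond the scatter) and so, although propyl and 4-methoxyphenyl are very different groups, compound 3 alone stands apart among the three. Nothing available here accounts for this difference.

The compounds shown leave open whether it matters where the nitrogen sits in the aromatic ring, a question that pyridin-3-yl would address. They also leave open how a cyclohexyl group or an amine such as piperidin-4-yl would fare on this saturated chain carbon.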